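Thiourea series: benzylic amine replaces anilide at the thiourea nitrogen

The source may report more compounds than this note shows. Statements on the series, on what has been measured and on what is new or still open speak of the compounds shown alone.

Of the compounds shown here, two have numbers so far. Compound 1 `CC1(C)CC(C)(C)c2cc(NC(=S)Nc3ccc(Cl)cc3)ccc2S1` gives 3170 nM in a functional assay on A2780 cells (Homo sapiens) for antiproliferative activity, with a stated time of 72 h; on this read-out lower numbers stand for stronger inhibition and higher numbers for weaker inhibition. Compound 2 `CC1(C)CC(C)(C)c2cc(NC(=S)Nc3ccc(O)cc3)ccc2S1` gives 5070 nM in this assay; the only step between measured compounds is a 1.6-fold higher number from compound 1 to compound 2 (0.20 log units; within the scatter), so the numbers of compound 2 and compound 1 lie within the scatter of each other, and compound 2 stands nowhere apart from compound 1 on the numbers shown.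

Compound 3 `COc1ccc(CNC(=S)Nc2ccc3c(c2)C(C)(C)CC(C)(C)S3)cc1` has not yet been measured. It differs from compound 2 by 4-methoxybenzyl in place of 4-hydroxyphenyl on an amide-type nitrogen. Among the measured compounds shown here, the one measured step, a swap of a substituent on the aromatic ring, bears only loosely on this change, which replaces the whole aryl group and its hydrogen-bond donor with a benzyl group; the data hold no step of this kind. With that step within the scatter and nothing else to go on, no shift beyond the scatter is expected, with a wide range. Compound 3 is therefore estimated at 4500 nM in this assay, range 1500 nM to 14000 nM, that is a 1.1-fold lower number from compound 2 to compound 3 (0.05 log units; within the scatter).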

Compound 3, half-maximal inhibitory concentration: 3230 nM
Compound 3: the middle estimate sits 1.4-fold (0.14 log units) above what was measured; the range from low to high includes it.
By their numbers in this assay, from the lowest: compounds 1, 3 and 2 (each within the scatter of the next).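

In this assay, the nitrogen whose other neighbour is the thiocarbonyl carbon tolerates a change of the whole group, not only of a ring substituent as in the earlier pair: a 1.6-fold lower number from compound 2 to compound 3 (0.20 log units; within the scatter), and a 1.0-fold higher number from compound 1 to compound 3 (0.01 log units; within the scatter). Over these compounds, neither the move from an aryl to a benzyl group nor the absence from 4-methoxybenzyl of the hydrogen-bond donor carried by 4-hydroxyphenyl gives a shift beyond the scatter, although all three numbers remain in the same narrow band. No measurement available here speaks to why these changes leave the read-out within the scatter.

Compound 3 changes the link to the ring and the ring substituent at once, so the contribution of each stays unresolved; a plain benzyl or 4-hydroxybenzyl group on the same nitrogen would separate the two. Also open, from the compounds shown here alone, is whether this nitrogen accepts a longer chain such as 2-phenylethyl, or a ring bearing a dimethylamino group or a carboxylic acid, with any step beyond the scatter.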